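A few compounds are considered here, and "the series" means these few. Any claim that something is new, unique, unknown or untested is made for them only; others in the source may bear on it.

In a functional assay on MGC-803 cells (Homo sapiens) for inhibition, read by MTT assay, with a stated time of 48 h (a higher number here means a weaker inhibitor, a lower number a stronger inhibitor), three compounds sharing one core have been measured. Compound 1 `C/C=C/C=C/C(=O)N(Cc1ccc(OC)c(O)c1)c1cc(OC)c(OC)c(OC)c1` gives 140 nM, compound 2 `COc1ccc(CN(C(=O)CO)c2cc(OC)c(OC)c(OC)c2)cc1O` gives 160 nM, and compound 3 `COc1ccc(CN(C(=O)CN=[N+]=[N-])c2cc(OC)c(OC)c(OC)c2)cc1O` gives 120 nM. Compound 3 thus stands within the scatter of both other compounds, and the numbers do not separate the three. Compound 4 `COc1ccc(CN(C(=O)CCCl)c2cc(OC)c(OC)c(OC)c2)cc1O` has chloromethyl in place of azido on a saturated chain carbon bound to a carbonyl carbon.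

For the measured compounds named here, three measured steps bear on this change. Two replace the penta-1,3-dien-1-yl group, giving a 1.1-fold higher number from compound 1 to compound 2 (0.06 log units; within the scatter) and a 1.2-fold lower number from compound 1 to compound 3 (0.07 log units; within the scatter). The third, at the same place as the new change, gives a 1.3-fold lower number from compound 2 to compound 3 (0.12 log units; within the scatter). Going by the values given here, none of the three leaves the scatter, although no measured compound carries chloromethyl, so that group itself remains untested. No change beyond the scatter is therefore expected in this assay, and no direction can be favoured. The expected step is a 1.1-fold higher number from compound 3 to compound 4 (0.03 log units; within the scatter). Compound 4 is estimated at 130 nM, with an expected range of 60 nM to 290 nM.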

Compound 4, half-maximal inhibitory concentration: 140 nM
Compound 4: the middle estimate sits 1.1-fold (0.03 log units) below what was measured; the measured number falls inside the stated range.
By their numbers in this assay, from the lowest: compounds 3, 1, 4 and 2 (each within the scatter of the next).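

At this position, on a saturated chain carbon bound to a carbonyl carbon, chloromethyl is now a third group alongside azido and hydroxy, and neither exchange separates the compounds: the exchange for azido gives (a 1.2-fold higher number from compound 3 to compound 4 (0.07 log units; within the scatter)) and the exchange for hydroxy gives (a 1.1-fold lower number from compound 2 to compound 4 (0.06 log units; within the scatter)). The larger replacement of penta-1,3-dien-1-yl by 2-chloroethyl on a carbonyl carbon likewise separates nothing in this assay (no change at the digits printed from compound 1 to compound 4 (within the scatter)). All four groups on the carbonyl carbon therefore read alike here, and nothing available speaks to the reason for this.

Going by these compounds, whether an amine, a carboxylic acid or a longer chain at this position would leave the scatter stays open. On these data alone, all four compounds share one core, so the outcome of a change elsewhere on it is also open.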